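The compounds below may be only part of what the source reports. "The series", "measured", "known", "first", "only" and "open" are said of these compounds alone.

Going by the values given here, in an assay on CHO cells for displacement of a labelled ligand from prostaglandin D2 receptor 2 (Homo sapiens), read by scintillation counting (on this read-out lower numbers stand for stronger inhibition and higher numbers for weaker inhibition), compound 1 `Cc1ccc(S(=O)(=O)N(C)CC(C)C)cc1C#Cc1cc(Cl)ccc1OCC(=O)O` gives 4.2 nM, the lowest number of the three measured so far. Compound 3 `CS(=O)(=O)c1cccc(C#Cc2cc(Cl)ccc2OCC(=O)O)c1` gives 15 nM in this assay, and compound 2 `O=C(O)COc1ccc(Cl)cc1C#Cc1ccccc1` gives 108 nM. Among the compounds with values here, the one single-point step available is a 7.2-fold lower number from compound 2 to compound 3 (0.86 log units; beyond the scatter). Compound 4 `Cc1ccc(S(=O)(=O)CCO)cc1C#Cc1cc(Cl)ccc1OCC(=O)O` differs from compound 1 in one place: 2-hydroxyethyl in place of isobutyl(methyl)amino on a sulfonyl sulfur. Within the data shown here, no measured step exchanges one group for another on a sulfonyl sulfur; the step from compound 2 to compound 3 shows only that a methylsulfonyl group in place of hydrogen lowers the number, and compound 4 keeps a sulfonyl. For compound 4 a step toward a higher number is expected, a 2.9-fold higher number from compound 1 to compound 4 (0.46 log units; beyond the scatter), beyond the scatter yet smaller than the gap between compound 1 and compound 2. Compound 4 is therefore estimated at 12 nM, within 4 nM to 40 nM.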

Compound 4, inhibition constant: 19 nM
Compound 4: the middle estimate sits 1.6-fold (0.20 log units) below what was measured; low and high end bracket the measured number.
By their numbers in this assay, from the lowest: compound 1; then compounds 3 and 4 (each within the scatter of the next); then compound 2.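

On the sulfonyl sulfur, one group exchanged for another gives a 4.5-fold higher number from compound 1 to compound 4 (0.66 log units; beyond the scatter) and so shows that this place affects the number, though only modestly. The entering 2-hydroxyethyl is the smaller group and brings a hydrogen-bond donor that isobutyl(methyl)amino lacks. No evidence is available that ties the step to either difference.

Size and the hydroxyl cannot be told apart from these compounds. Going by these compounds, a plain ethyl, a 2-methoxyethyl or a longer chain ending in an amine or a carboxylic acid on the same sulfonyl sulfur remains open.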